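A few compounds are considered here, and "the series" means these few. Any claim that something is new, unique, unknown or untested is made for them only; others in the source may bear on it.

Series of three measured analogues around a shared core, with a fourth to be assessed. Compound 1 `O=C(CN(c1nc(Cl)nc2[nH]cnc12)C1CC1)NCC(=O)OCc1ccccc1` gives 41.9% in a functional assay on the whole organism (Tail, strain ICR) with Mus musculus as the target, in the tail flick test, with a stated time of 60 min, at a dose of 25 umol/kg by the oral route; a lower number here means a weaker effect, a higher number a stronger effect of the compound at the dose given. Compound 2 `O=C(CN(c1ncnc2c1ncn2C1CCCCO1)C1CC1)NCC(=O)OCc1ccccc1` gives 40.4% in this assay, and compound 3 `O=C(O)CNC(=O)CN(c1nc(Cl)nc2[nH]cnc12)C1CC1` gives 38.9%; all three values sit within the scatter of one another, so no ordering among them can be read. Compound 1 stands at the top of the three numbers, but its gap to compound 2 and its gap to compound 3 are both within the scatter.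

Among the measured compounds shown here, the only single-point step measured so far is a number 3 percentage points lower from compound 1 to compound 3 (within the scatter), which shows that removing the benzyl ester leaves the read-out essentially where it was.

The next compound, compound 4 `NC(=O)CC[C@H](NC(=O)CN(c1nc(Cl)nc2[nH]cnc12)C1CC1)C(=O)OCc1ccccc1`, differs from compound 1 by 2-carbamoylethyl in place of hydrogen on a saturated chain carbon bound to an amide-type nitrogen and a carbonyl carbon. For the measured compounds named here, no measured step touches that saturated chain carbon, so the only bearing comes from the flat picture of the series: the ester change from compound 1 to compound 3 and the core variation to compound 2 both left the read-out within the scatter. On that basis a step of a number 1.9 percentage points lower from compound 1 to compound 4 (within the scatter) is expected, that is, nothing beyond the scatter in either direction. Compound 4 is therefore estimated at 40%, with a range from 28% to 52%.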

Compound 4, a percentage reported as activity, at one dose (the size of the read-out at that dose, not a potency): 33.1%
Compound 4: the middle estimate sits 6.9 percentage points above what was measured; measured number inside the range.
By their numbers in this assay, from the lowest: compounds 4, 3, 2 and 1 (each within the scatter of the next).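

In this assay, 2-carbamoylethyl in place of hydrogen on a saturated chain carbon bound to an amide-type nitrogen and a carbonyl carbon gives a number 8.8 percentage points lower from compound 1 to compound 4 (within the scatter) and thus provides the only reading at this position among the compounds shown. Compound 4 keeps the shared core and the benzyl ester of compound 1, so this step isolates the position, and the read-out at the dose given stays within the scatter even with the added chain. No supporting measurement is available to explain this result.

Open questions at this carbon are whether a methyl group, a longer chain, an amine or a carboxylic acid at the end of the chain in place of the carbamoyl group, or the opposite configuration would move the read-out beyond the scatter. Also open, as far as these compounds go, is whether 2-carbamoylethyl behaves the same way when the benzyl ester is replaced by the free carboxylic acid, or when it is paired with the core of compound 2.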